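A Carbamate Replaces an Alkyl Chain on the Ring Amine

The compounds below may be only part of what the source reports. "The series", "measured", "known", "first", "only" and "open" are said of these compounds alone.

Compound 1 `Cc1ccc(-c2c3c(nc(C)c2C(OC(C)(C)C)C(=O)O)CCN(CCCC2CCCC2)C3)cc1` was tested in an ADME assay on MT2 cells (Homo sapiens) for cytotoxicity, read by XTT assay, with a stated time of 4 days; on this read-out lower numbers stand for higher toxicity in this test and higher numbers for lower toxicity in this test. In this assay compound 1 gives > 40000 nM, which is a limit of the assay rather than a number. Two related compounds were run in the same test. Compound 2 `Cc1ccc(-c2c3c(nc(C)c2[C@H](OC(C)(C)C)C(=O)O)CCN(CCCc2ccccc2)C3)cc1` gives > 40000 nM in this assay, again a limit. Compound 3 `Cc1nc2c(c(-c3cc(F)c4c(c3C)CCCO4)c1[C@H](OC(C)(C)C)C(=O)O)CN(CC1CC1c1ccccc1)CC2` gives > 40000 nM in this assay, also a limit. Compound 1 therefore stands where every measured compound here stands: the limit of > 40000 nM in this assay, at which 3 of the 3 values shown sit. Among the measured compounds shown here, no pair of these three compounds differs in a single place, so no step between measured compounds can be read off, and nothing beyond the shared limit separates them.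

The next compound, compound 4 `COC(=O)N1CCc2nc(C)c(C(OC(C)(C)C)C(=O)O)c(-c3ccc(C)cc3)c2C1`, remains to be measured. It differs from compound 1 in one place: methoxycarbonyl in place of 3-cyclopentylpropyl on an amine nitrogen in a ring. Since compound 1 sits at the limit recorded in the limit of > 40000 nM in this assay, at which 3 of the 3 values shown sit, compound 4 is expected to return a limit as well, and the expected change is none beyond the scatter. The expected value for compound 4 in this assay is 40000 nM, within a range from 20000 nM to 80000 nM. Accordingly the estimated step of a number no higher from compound 1 to compound 4 (the limit leaves the size open) is expected to lie within the usual scatter.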

Compound 4, half-maximal cytotoxic concentration: > 40000 nM
Compound 4: a limit, no number; the forecaster's own chance of this, stated with the estimate: 85%; the middle value lies on the limit itself.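

Compound 4 gives > 40000 nM in this assay, which is a limit of the assay and not a number. Compound 1 gives > 40000 nM there, also a limit, so no step can be read between compound 1 and compound 4: the limit of > 40000 nM in this assay, at which 4 of the 4 values shown sit.

The compounds shown leave open how far any of them differ in cytotoxicity, since none gives a number.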